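Fluoro for methyl on two benzothiazole-bearing cores

The compounds below may be only part of what the source reports. "The series", "measured", "known", "first", "only" and "open" are said of these compounds alone.

In a functional assay on MCF7 cells (Homo sapiens) for cytotoxicity, read by sulforhodamine B assay, with a stated time of 48 h (a higher number here means a weaker inhibitor of growth, a lower number a stronger inhibitor of growth), compound 1 `Cc1ccc(-c2ccc(C)n2-c2ccc(-c3nc4ccccc4s3)cc2)cc1` gives 2500 nM. Compound 2 `Cc1ccc(-c2ccc(F)cc2)n1-c1ccc(-c2nc3ccccc3s2)cc1` carries the change fluoro in place of methyl on an aromatic carbon and in this assay gives 2620 nM; the step of a 1.0-fold higher number from compound 1 to compound 2 (0.02 log units; within the scatter) is small. Compound 3 `COc1cc2nc(-c3ccc(-n4c(C)ccc4-c4ccc(C)cc4)cc3)sc2c(OC)c1OC` rests on a different core; the difference between the two cores is not broken down here. In this assay compound 3 gives 2910 nM, a number that lies close to those of compound 1 and compound 2. Compound 4 `COc1cc2nc(-c3ccc(-n4c(C)ccc4-c4ccc(F)cc4)cc3)sc2c(OC)c1OC` is not yet measured and differs from compound 3 by fluoro in place of methyl on an aromatic carbon, the same change as from compound 1 to compound 2. Since that earlier step moved the number only within the scatter, the step of a 1.0-fold higher number from compound 3 to compound 4 (0.01 log units; within the scatter) is expected to be of similar size. Compound 4 is therefore estimated at 3000 nM, with a likely range from 1500 nM to 6000 nM.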

Compound 4, concentration for 50% growth inhibition: 2670 nM
Compound 4: middle estimate off by 1.1-fold (0.05 log units), on the high side; the measured number falls inside the stated range.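

In this assay, the exchange of 4-methylphenyl for 4-fluorophenyl gives a 1.1-fold lower number from compound 3 to compound 4 (0.04 log units; within the scatter). Set beside the earlier step, fluoro in place of methyl reads alike on the two cores: the same change on two cores in this assay, a 1.0-fold higher number (0.02 log units; within the scatter) from compound 1 to compound 2 and a 1.1-fold lower number (0.04 log units; within the scatter) from compound 3 to compound 4, 1.1-fold (0.06 log units) apart, within the scatter of two such steps. This shows that the change carries across these two cores in this one assay, leaving the number within the scatter each time; it does not show that the same would hold on any other core or in any other cell line.

The compounds shown leave open whether another group at that place, such as an amine, a carboxylic acid or a longer chain, would move the number beyond the scatter. They also leave open what the methoxy groups contribute to the difference between the two cores.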